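Halogen swap on the fused ring in the thioether series

The source may report more compounds than this note shows. Statements on the series, on what has been measured and on what is new or still open speak of the compounds shown alone.

Compound 1 `CCOC(=O)Sc1nc2cc(-n3nc(C(C)(C)C)sc3=O)c(F)cc2s1`: 40 nM
Compound 2 `CCOC(=O)CCCSc1nc2cc(-n3nc(C(C)(C)C)sc3=O)c(F)cc2s1`: 8670 nM
Compound 3 `C#CCSc1nc2cc(-n3nc(C(C)(C)C)sc3=O)c(F)cc2s1`: 9730 nM

In an assay on isolated protein for inhibition of protoporphyrinogen oxidase (Homo sapiens), read by capillary electrophoresis (on this read-out lower numbers stand for stronger inhibition and higher numbers for weaker inhibition), compound 3 sits at the top end of the three numbers, together with compound 2 (a 1.1-fold higher number from compound 2 to compound 3 (0.05 log units; within the scatter)), and far from compound 1 (a 240-fold higher number from compound 1 to compound 3 (2.39 log units; beyond the scatter); also a 220-fold higher number from compound 1 to compound 2 (2.34 log units; beyond the scatter)). Compound 4 `C#CCSc1nc2cc(-n3nc(C(C)(C)C)sc3=O)c(Cl)cc2s1` differs from compound 3 by chloro in place of fluoro on an aromatic carbon. Within the data shown here, all three measured steps concern the group on the sulfur; none touches the halogen on the fused ring, so no measured step bears directly on this change. With nothing to anchor a shift, the expected step is a 1.2-fold lower number from compound 3 to compound 4 (0.09 log units; within the scatter), that is none beyond the scatter. Compound 4 is therefore estimated at 8000 nM, with a range of 2500 nM to 25000 nM.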

Compound 4, inhibition constant: 21400 nM
For compound 4 the middle estimate is 2.7-fold (0.43 log units) below the measured one, and the stated range covers the measured number.
By their numbers in this assay, from the lowest: compound 1; then compounds 2 and 3 (each within the scatter of the next); then compound 4.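

Chloro in place of fluoro gives a 2.2-fold higher number from compound 3 to compound 4 (0.34 log units; beyond the scatter) in this assay and so shows that this aromatic carbon, ortho to a large group, responds to the halogen. With propargyl on the sulfur, fluoro gives the lower number of the two halogens, although this step is much smaller than a 240-fold higher number from compound 1 to compound 3 (2.39 log units; beyond the scatter) on the sulfur. No available evidence accounts for the shift.

From the compounds shown here alone, it remains open whether chloro gives a similar step with ethoxycarbonyl on the sulfur, as in compound 1. Going by these compounds, the effects of bromo, methyl or hydrogen at this carbon also remain open.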